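Removing the Ring Methyl: Compound 3 to Compound 4

The source may report more compounds than this note shows. Statements on the series, on what has been measured and on what is new or still open speak of the compounds shown alone.

Compound 3 `COc1cc(N2CCN(C(=O)N[C@@H](C)c3cccc4ccccc34)C[C@H]2C)ccc1-c1cnc(C)o1` stands level with compound 1 `COc1cc(N2CCN(C(=O)N[C@@H](C)c3cccc4ccccc34)CC2)ccc1-n1cnc(C)c1` and compound 2 `COc1cc(N2CCN(C(=O)N[C@@H](C)c3cccc4ccccc34)C[C@@H]2C)ccc1-c1cnc(C)o1` in an ADME assay on microsomes from liver (Rattus norvegicus) for metabolic stability, read by LC-MS; a higher number here means faster removal of the compound, a lower number slower removal: compound 3 gives 150 mL.min-1.g-1, compound 1 gives 150 mL.min-1.g-1, and compound 2 gives 150 mL.min-1.g-1. Within the data shown here, the only measured step, from compound 2 to compound 3 no change at the digits printed from compound 2 to compound 3 (within the scatter), showed no movement, and the sole evidence bearing on it is the fact that compounds 2 and 3 differ only in the configuration as drawn. Compound 4 `COc1cc(N2CCN(C(=O)N[C@@H](C)c3cccc4ccccc34)CC2)ccc1-c1cnc(C)o1` differs from compound 3 by hydrogen in place of methyl on a saturated ring carbon. Among the measured compounds shown here, no measured step removes this methyl; the one step available, a change of configuration at a saturated ring carbon, left the read-out unchanged. Compound 4 is therefore expected to show no step beyond the scatter no change at the digits printed from compound 3 to compound 4 (within the scatter). Compound 4 is estimated at 150 mL.min-1.g-1, within 75 mL.min-1.g-1 to 300 mL.min-1.g-1.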

Compound 4, intrinsic clearance in microsomes: 130 mL.min-1.g-1
The estimate for compound 4 lay 1.2-fold (0.06 log units) above the measured number; the measured number falls inside the stated range.
By their numbers in this assay, from the lowest: compounds 4, 1, 2 and 3 (each within the scatter of the next).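

In this assay the methyl on the saturated ring carbon can give way to hydrogen with the read-out staying within the scatter, with a 1.2-fold lower number from compound 3 to compound 4 (0.06 log units; within the scatter) and a 1.2-fold lower number from compound 2 to compound 4 (0.06 log units; within the scatter), so neither drawn configuration stands apart from the compound without the methyl. At a second place on the core, 2-methyl-1,3-oxazol-5-yl in place of 4-methyl-1H-imidazol-1-yl gives a 1.2-fold lower number from compound 1 to compound 4 (0.06 log units; within the scatter). Nothing given here explains these readings.

From the compounds shown here alone, whether an ethyl or aminomethyl group on this ring carbon would read differently remains open. So does whether any change to the shared core moves the number beyond the scatter.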